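This account rests on a few compounds, and the source may have more. Where it says the series, first, only, none or still open, it means among the compounds named here.

Compound 1 `O=C(CCCCCCc1ccccc1)c1nc(C(=O)C(F)(F)F)co1`: 123 nM
Compound 2 `O=C(CCCCCCc1ccccc1)c1nc(Cl)co1`: 2400 nM

In an assay on HEK-293T cells for inhibition of diacylglycerol lipase-alpha (Homo sapiens), read by colorimetric assay (on this read-out lower numbers stand for stronger inhibition and higher numbers for weaker inhibition), compound 2 gives the higher of the two numbers shown, and its only neighbour, compound 1, gives 123 nM. Within the data shown here, the one measured step is a 20-fold higher number from compound 1 to compound 2 (1.29 log units; beyond the scatter). Compound 3 `CSc1cnc(C(=O)CCCCCCc2ccccc2)o1` differs from compound 2 by 5-(methylsulfanyl)-1,3-oxazol-2-yl in place of 4-chloro-1,3-oxazol-2-yl on a carbonyl carbon. Among the measured compounds shown here, no measured step exchanges a chloro for a methylsulfanyl group, so that step does not bear on this change directly. Compound 3 is therefore expected to stay close to compound 2, with a step of a 1.2-fold lower number from compound 2 to compound 3 (0.08 log units; within the scatter). The estimate for compound 3 is 2000 nM, with a range from 600 nM to 7000 nM.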

Compound 3, half-maximal inhibitory concentration: > 10000 nM
Compound 3 ended at the assay's limit; the forecaster's own chance of this, stated with the estimate: 10%; at least 5.0-fold (0.69 log units) between middle value and limit.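

In this assay, replacing 4-chloro-1,3-oxazol-2-yl with 5-(methylsulfanyl)-1,3-oxazol-2-yl on the carbonyl carbon is not a neutral exchange: it gives an at least 4.1-fold higher number from compound 2 to compound 3 (0.61 log units; beyond the scatter). Compound 3 gives a limit of the assay, not a number: the limit of > 10000 nM in this assay, at which 1 of the 3 values shown sits. As far as these compounds go, the full size of this step therefore stays unknown, but this position clearly does not accept every replacement for the chloro-bearing ring.

The group and its ring number change together, so the two effects cannot be separated. A 5-chloro-1,3-oxazol-2-yl or 4-(methylsulfanyl)-1,3-oxazol-2-yl group would show which change matters.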